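From Anilino to Propyl on the Amide Nitrogen

A few compounds are considered here, and "the series" means these few. Any claim that something is new, unique, unknown or untested is made for them only; others in the source may bear on it.

In a functional assay on cells (Cancer cell lines, Homo sapiens) for inhibition, with a stated time of 48 h (a lower number here means a stronger inhibitor of growth, a higher number a weaker inhibitor of growth), compound 2 `O=C(Nc1sc2c(c1C(=O)NNc1ccccc1)CCCCC2)NS(=O)(=O)c1ccccc1` gives 26300 nM, and this is the only plain number shown for the series. Compound 1 `NNC(=O)c1c(NC(=O)NS(=O)(=O)c2ccccc2)sc2c1CCCCC2` reaches only a limit of the assay, > 100000 nM. It thus sits at the limit of > 100000 nM in this assay, at which 1 of the 2 values shown sits. Among the measured compounds shown here, the single measured step between them is an at least 3.8-fold lower number from compound 1 to compound 2 (0.58 log units; beyond the scatter), a change on the amine nitrogen that moved the number beyond the usual scatter.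

Compound 3 `CCCNC(=O)c1c(NC(=O)NS(=O)(=O)c2ccccc2)sc2c1CCCCC2` differs from compound 2 at the same nitrogen: propyl in place of anilino on an amide-type nitrogen. The aromatic ring and the hydrogen-bond donor of compound 2 go, and a short chain takes their place. Taking the phenyl away from compound 2 would give compound 1, which only reached a limit, so the propyl in compound 3 is expected to leave the number higher than that of compound 2 rather than lower. The expected step is a 2.7-fold higher number from compound 2 to compound 3 (0.43 log units; beyond the scatter), a weakening. Compound 3 is therefore estimated at 70000 nM, with a range from 25000 nM to 200000 nM, and it may itself end at a limit.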

Compound 3, concentration for 50% growth inhibition: 80300 nM
Compound 3: middle estimate off by 1.1-fold (0.06 log units), on the low side; low and high end bracket the measured number.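

Compound 3 shows that on this amide-type nitrogen, the anilino group can be exchanged for a propyl chain with no ring, and the exchange has a cost in this assay: the result is a 3.1-fold higher number from compound 2 to compound 3 (0.48 log units; beyond the scatter), so of these two groups anilino gives the stronger inhibition of growth. The comparison with the amino compound is less informative, as the change is an at least 1.2-fold lower number from compound 1 to compound 3 (0.09 log units; that floor lies within the scatter), which means that propyl and amino cannot be placed in order from these data. Compound 1 is held at a limit of the assay, not at a plain number: the limit of > 100000 nM in this assay, at which 1 of the 3 values shown sits.

The exchange from anilino to propyl changes the aromatic ring, the chain and the extra nitrogen all at once, so the compounds shown do not say which of these accounts for the step. A phenyl group set directly on the amide nitrogen, a benzyl group, or a longer chain such as hexyl in the same place would help to pull these parts apart.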